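A few compounds are considered here, and "the series" means these few. Any claim that something is new, unique, unknown or untested is made for them only; others in the source may bear on it.

Compound 3, `CC(C)(NC(=O)c1cc(F)cc2cc(-c3ccc(Cl)cc3)oc12)c1nnn[nH]1`, carries a fluoro on the shared core and an amide-type nitrogen bearing a 1-(1H-tetrazol-5-yl)-1-methylethyl group; in an assay on isolated protein for inhibition of endoplasmic reticulum aminopeptidase 2 (Homo sapiens) (on this read-out lower numbers stand for stronger inhibition and higher numbers for weaker inhibition), compound 3 has "not determined" (no result reported), so its position on the scale cannot be stated. The two other compounds from the same series give only limits in this assay. Compound 1, `CC(C)(NC(=O)c1cccc2cc(-c3ccc(Cl)cc3)oc12)C(=O)O`, reaches no measurable inhibition and reports > 30000 nM, which is a limit of the assay rather than a number. Compound 2, `CC(C)(NC(=O)c1cccc2c(Br)c(-c3ccc(Cl)cc3)oc12)C(=O)O`, likewise reports > 30000 nM, again a limit. Among the measured compounds shown here, the one measured step, a step that the two limits leave unreadable from compound 1 to compound 2, bromo in place of hydrogen on an aromatic carbon, therefore cannot be read in size, because both values sit at the limit of > 30000 nM in this assay, at which 2 of the 3 values shown sit.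

Compound 4, `O=C(NC1(C(=O)O)CCCC1)c1cc(F)cc2cc(-c3ccc(Cl)cc3)oc12`, differs from compound 3 by 1-carboxycyclopentyl in place of 1-(1H-tetrazol-5-yl)-1-methylethyl on an amide-type nitrogen. For the measured compounds named here, no measured step concerns this exchange of the 1-(1H-tetrazol-5-yl)-1-methylethyl group for 1-carboxycyclopentyl, and the two measured compounds that carry a carboxylic acid on the amide-type nitrogen, compound 1 and compound 2, both fall at the limit. On that basis compound 4 is expected to show weak inhibition in this assay as well, with an estimated value of 30000 nM and a range from 5000 nM to 100000 nM, most likely reported as a limit rather than a number.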

Compound 4, half-maximal inhibitory concentration: > 30000 nM
Compound 4: only a limit was reported; the forecaster's own chance of this, stated with the estimate: 70%; the middle value lies on the limit itself.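

In this assay compound 4 gives > 30000 nM, which is a limit and not a number. No new step can be read from compound 4, which stands with compound 1 and compound 2: the limit of > 30000 nM in this assay, at which 3 of the 4 values shown sit. The compounds shown leave open which change on the shared core or the amide-type nitrogen, if any, would give a value that is a number rather than a limit.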